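A few compounds are considered here, and "the series" means these few. Any claim that something is new, unique, unknown or untested is made for them only; others in the source may bear on it.

Compound 1 `COc1ccc(C2N=C(SCc3cccc(Cl)c3)NC(C)=C2C(=O)Nc2ccc(F)cc2)cc1OC` and compound 2 `COc1ccc(C2N=C(SCc3ccc(Cl)cc3)NC(C)=C2C(=O)Nc2ccc(F)cc2)cc1OC` share a core and differ in one place. In a functional assay on the whole organism (artery, strain albino) with Rattus norvegicus as the target, with a stated time of 30 min, at a dose of 10 mg/kg by the oral route (a higher number here means more inhibition at the dose given (going by the name of the read-out), a lower number less inhibition), compound 1 gives 5.2%, and compound 2 gives 5.7%. The change from compound 1 to compound 2 is 4-chlorophenyl in place of 3-chlorophenyl on a saturated chain carbon bound to a sulfur, and it made the step of a number 0.5 percentage points higher from compound 1 to compound 2 (within the scatter). Compound 3 `CC1=C(C(=O)Nc2ccc(Br)cc2)C(c2ccc(Cl)cc2Cl)N=C(SCc2cccc(Cl)c2)N1` has a different core; in this assay compound 3 gives 3.1%. The difference between the core of compound 3 and the core of compound 1 is not broken down here. Compound 4 `CC1=C(C(=O)Nc2ccc(Br)cc2)C(c2ccc(Cl)cc2Cl)N=C(SCc2ccc(Cl)cc2)N1` has not yet been measured in this assay. It differs from compound 3 by 4-chlorophenyl in place of 3-chlorophenyl on a saturated chain carbon bound to a sulfur, the same change that was made from compound 1 to compound 2. The step expected for compound 4 is a number 0.5 percentage points higher from compound 3 to compound 4 (within the scatter), resting on the earlier step of a number 0.5 percentage points higher from compound 1 to compound 2 (within the scatter) of compound 2. Compound 4 is therefore estimated to give 3.6% in this assay, between 0% and 12%.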

Compound 4, a percentage reported as inhibition, in the whole organism at one dose (the size of the read-out at that dose, not a potency): 6.7%
Beside the measured number, compound 4's estimate is 3.1 percentage points below it, within the range that was stated.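

In this assay, 4-chlorophenyl in place of 3-chlorophenyl on the saturated chain carbon bound to a sulfur gave a number 3.6 percentage points higher from compound 3 to compound 4 (within the scatter). Set beside the earlier step on the other core, the result gives no sign that the change behaves differently on the two cores: the same change on two cores in this assay, a number 0.5 percentage points higher (within the scatter) from compound 1 to compound 2 and a number 3.6 percentage points higher (within the scatter) from compound 3 to compound 4, 3.1 percentage points apart, within the scatter of two such steps. Within the data shown here, this shows only that the two steps agree within the scatter; as neither stands clear of the scatter, it does not show that the change increases inhibition on either core, or that it would carry over to a further core.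

The compounds shown carry only chlorobenzyl groups on the sulfur. From the compounds shown here alone, what an unsubstituted benzyl, a 4-methoxybenzyl or a longer chain there would give remains open.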